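Methoxy to chloro on the benzyl group of compound 3

A few compounds are considered here, and "the series" means these few. Any claim that something is new, unique, unknown or untested is made for them only; others in the source may bear on it.

Compound 1, `COc1ccc(Cc2nnc(NC(=O)/C(C#N)=C/c3ccccc3OS(=O)(=O)c3ccccc3[N+](=O)[O-])s2)cc1`, gives 25% in a functional assay on HL-60 cells (Homo sapiens) for inhibition, read by CCK-8 assay, with a stated time of 48 h, tested at 20 uM; a higher number here means more inhibition of growth at the concentration tested, a lower number less inhibition of growth.
Compound 2, `COc1ccc(Cc2nnc(NC(=O)/C(C#N)=C/c3ccccc3OS(=O)(=O)c3ccc(Cl)cc3)s2)cc1`, gives 20% in this assay.
Compound 3, `COc1ccc(Cc2nnc(NC(=O)/C(C#N)=C/c3ccccc3OS(=O)(=O)c3ccc(F)cc3)s2)cc1`, gives 25% in this assay.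

Compound 3 sits level with compound 1: no change at the digits printed from compound 1 to compound 3 (within the scatter). Against compound 2 the picture is the same, since a number 5 percentage points higher from compound 2 to compound 3 (within the scatter). Together compound 1 and compound 3 hold the highest numbers of the three, but all three numbers lie within the scatter of one another, so no ordering can be claimed among them.

The measured steps all change the aryl group on the sulfonyl sulfur: a number 5 percentage points lower from compound 1 to compound 2 (within the scatter) and no change at the digits printed from compound 1 to compound 3 (within the scatter), each within the scatter. None of them touches the group that changes in the next compound. Compound 4, `N#C/C(=C\c1ccccc1OS(=O)(=O)c1ccc(F)cc1)C(=O)Nc1nnc(Cc2ccc(Cl)cc2)s1`, differs from compound 3 in one place: chloro in place of methoxy on an aromatic carbon. Among the compounds with values here, no measured pair shows what this position does, so the expectation can rest only on the fact that the three measured values cluster closely.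

The step from compound 3 to compound 4 is therefore expected to be no change at the digits printed from compound 3 to compound 4 (within the scatter), with no movement beyond the scatter. Compound 4 is estimated to give 25% in this assay, expected between 10% and 42%.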

Compound 4, percent growth inhibition at one concentration: 20%
The estimate for compound 4 lay 5 percentage points above the measured number; the range from low to high includes it.
By their numbers in this assay, from the lowest: compounds 2, 4, 1 and 3 (each within the scatter of the next).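

Within the data shown here, this is the first step at the benzyl end of the molecule, since the earlier steps changed only the aryl group on the sulfonyl sulfur. Replacing 4-methoxybenzyl with 4-chlorobenzyl in this assay gives a number 5 percentage points lower from compound 3 to compound 4 (within the scatter), so exchanging methoxy, with its two heavy atoms and one hydrogen-bond acceptor, for chloro, a single heavy atom with no acceptor, produces no change that can be read at this position, and the methoxy is not needed to keep the number within the scatter of compound 3. No supporting measurement is available to explain this result.

On these data alone, only methoxy and chloro appear at this position, and only with the 4-fluorophenyl group on the sulfonyl sulfur, so it remains open whether the same exchange would read the same way with another aryl group there. As far as these compounds go, it also remains open whether a larger change at this position, such as an amine, a carboxylic acid or a longer alkyl chain in place of the chloro, would move the number beyond the scatter.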